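Exchanging the Amide of Compound 1 for an Ester

This account rests on a few compounds, and the source may have more. Where it says the series, first, only, none or still open, it means among the compounds named here.

Three measured compounds share one core. In an assay for inhibition of 15-hydroxyprostaglandin dehydrogenase [NAD(+)] (Homo sapiens), read by fluorescence, with a stated time of 15 min, in the presence of a further agent that is not named here (on this read-out lower numbers stand for stronger inhibition and higher numbers for weaker inhibition), compound 1 `CCCC[S+]([O-])c1sc2nc(-c3nccs3)cc(-c3ccc(C(=O)N(C)C)cc3)c2c1N` gives 5.9 nM, compound 2 `CCCC[S+]([O-])c1sc2nc(-c3nccs3)cc(-c3cccc(CO)c3)c2c1N` gives 4.3 nM, and compound 3 `Nc1c([S+]([O-])CCCF)sc2nc(-c3cccs3)cc(-c3ccccc3)c12` gives 6.1 nM. Compound 1 holds the second highest of these three numbers, yet its gaps to compound 3 and to compound 2 both lie within the scatter of this assay, so the three read as equivalent. Compound 4 `CCCC[S+]([O-])c1sc2nc(-c3nccs3)cc(-c3ccc(COC(=O)CN(C)C)cc3)c2c1N` differs from compound 1 in one place: ((((dimethylamino)methyl)carbonyl)oxy)methyl in place of dimethylcarbamoyl on an aromatic carbon. Going by the values given here, no measured pair shows a step of this kind, so the expectation rests on the narrow spread of the three values alone. The expected step of a 1.2-fold higher number from compound 1 to compound 4 (0.07 log units; within the scatter) is estimated as none beyond the scatter. For compound 4 the estimated value in this assay is 7 nM, within a range from 2.5 nM to 20 nM.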

Compound 4, half-maximal inhibitory concentration: 3.5 nM
Estimate against measurement, compound 4: 2.0-fold (0.30 log units) above; the range from low to high includes it.
By their numbers in this assay, from the lowest: compounds 4, 2, 1 and 3 (each within the scatter of the next).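

In this assay, replacing dimethylcarbamoyl with ((((dimethylamino)methyl)carbonyl)oxy)methyl on this aromatic carbon gives a 1.7-fold lower number from compound 1 to compound 4 (0.23 log units; within the scatter). Going by these compounds alone, this is the first direct comparison at this position, and it shows that the larger ester-bearing group, with its added hydrogen-bond acceptors, keeps the number within the scatter of the amide. Nothing available here accounts for this result. Going by these compounds, it remains open whether a carboxylic acid or a longer chain ending in an amine would also hold the number at this position.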